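A few compounds are considered here, and "the series" means these few. Any claim that something is new, unique, unknown or untested is made for them only; others in the source may bear on it.

Compounds measured so far:
compound 1 `Cc1ccc(N2CCN(C(=O)C3CCN(C(=O)c4ccc(S(C)(=O)=O)c([N+](=O)[O-])c4)CC3)CC2)cc1`, > 27000 nM
compound 2 `CN1CCN(C(=O)C2CCN(C(=O)c3ccc(S(C)(=O)=O)c([N+](=O)[O-])c3)CC2)CC1`, > 27000 nM

In an ADME assay on HepG2 cells (Homo sapiens) for cytotoxicity, read by CellTiter-Glo and ATP content, with a stated time of 72 h (on this read-out higher numbers stand for an effect only at larger amounts of compound and lower numbers for an effect already at smaller amounts), compound 1 gives > 27000 nM, which is a limit of the assay and not a number. In this assay compound 2 gives > 27000 nM, again a limit and not a number. Both values sit at the limit of > 27000 nM in this assay, at which 2 of the 2 values shown sit. Among the measured compounds shown here, the one step between them, a step that the two limits leave unreadable from compound 1 to compound 2, therefore cannot be read in size or direction, and compound 2 stands only on a limit with no numbered value beside it.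

Compound 3 `CS(=O)(=O)c1ccc(C(=O)N2CCC(C(=O)N3CCc4ccccc4C3)CC2)cc1[N+](=O)[O-]` differs from compound 2 in one place: 1,2,3,4-tetrahydroisoquinolin-2-yl in place of 4-methylpiperazin-1-yl on a carbonyl carbon. For the measured compounds named here, no measured step bears directly on this change; the one step available, a step that the two limits leave unreadable from compound 1 to compound 2, is unreadable, so the only guide is that both measured compounds sit at the limit. Going by the values given here, the change from compound 2 to compound 3 is expected to give a number no higher from compound 2 to compound 3 (the limit leaves the size open), that is, no step that can be told apart from the limit. Compound 3 is therefore expected to give 27000 nM in this assay, with a range from 10000 nM to 60000 nM, most likely reported again as a limit.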

Compound 3, half-maximal effective concentration: > 27000 nM
Compound 3: no number, only a limit (the forecaster's own chance of this, stated with the estimate: 75%); the middle value lies on the limit itself.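

In this assay compound 3 gives > 27000 nM as a limit and not a number. The step from compound 2 to compound 3 therefore cannot be read in size or direction, and compound 3 adds no comparison: the limit of > 27000 nM in this assay, at which 3 of the 3 values shown sit. The compounds shown leave open whether changing either group shifts the half-maximal effective concentration at all.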